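The source may hold more compounds than are shown below. What is called first, only, known or untested is meant among the compounds shown, and "the series" means these compounds.

Series notes. Compound 1 `Cc1cccc(N2CCN(CCCNc3nc(NCc4ccco4)c4ccccc4n3)CC2)c1C` has no result in a functional assay on A375P cells (Homo sapiens) for cytotoxicity, read by MTT assay, with a stated time of 2 days, tested at 10 uM (on this read-out lower numbers stand for less inhibition and higher numbers for more inhibition at the one concentration tested (going by the name of the read-out)), reported as "not determined" (no result reported). For the measured compounds named here, compound 2 `Fc1ccc2nc(NCCCCN3CCN(c4cccc(Cl)c4Cl)CC3)nc(NCc3ccco3)c2c1` gives 97.4% in this assay, the only number in hand for the series. Compound 3 `Cc1cccc(N2CCN(CCCCNc3nc(NCc4ccco4)c4cc(F)ccc4n3)CC2)c1C` differs from compound 2 by 2,3-dimethylphenyl in place of 2,3-dichlorophenyl on an amine nitrogen in a ring. Going by the values given here, no measured step covers this change, so the expected shift in this assay is none beyond the scatter, or at most a modest drop, because compound 2 already reads 97.4% and sits near the top of the read-out. Compound 3 is estimated at 90% in this assay, within 70% to 99%, an expected step of a number 7.4 percentage points lower from compound 2 to compound 3 (within the scatter).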

Compound 3, a percentage reported as inhibition, at one concentration (the size of the read-out at that concentration, not a potency): 97.6%
Beside the measured number, compound 3's estimate is 7.6 percentage points below it; the measured number falls inside the stated range.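

With 2,3-dimethylphenyl in place of 2,3-dichlorophenyl on the amine nitrogen in the ring, this assay shows a number 0.2 percentage points higher from compound 2 to compound 3 (within the scatter) and so does not separate the two groups at the one concentration tested. This position therefore accepts either pair of substituents without a change beyond the scatter in this read-out. No measured evidence bears on why this is so.

Both compounds read close to the top of the scale, which leaves any difference in potency between them open. Also open, going by these compounds, is how an unsubstituted phenyl or a pyridine ring on the same nitrogen would read.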